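This account rests on a few compounds, and the source may have more. Where it says the series, first, only, none or still open, it means among the compounds named here.

Values in an ADME assay on CEM-SS cells (Homo sapiens) for cytotoxicity, read by XTT assay; on this read-out higher numbers stand for lower toxicity in this test and lower numbers for higher toxicity in this test:
- compound 1 `NC(=O)c1cc(F)ccc1Cn1ccc2cc(C(=O)NO)ncc21`: > 10000 nM (a limit)
- compound 2 `CN(O)C(=O)c1cc2ccn(Cc3ccc(F)cc3F)c2cn1`: 135000 nM
- compound 3 `CN(O)C(=O)c1cc2ccn(Cc3ccc(F)cc3)c2cn1`: 200000 nM

Compound 1 gives > 10000 nM, which is a limit and not a number. That leaves two real numbers to place compound 3. It stands at 200000 nM, level within the scatter with compound 2 at 135000 nM, so the two cannot be ranked.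

Compound 4 `CC(C)CN(O)C(=O)c1cc2ccn(Cc3ccc(F)cc3)c2cn1` differs from compound 3 by isopropyl in place of hydrogen on a saturated chain carbon bound to an amide-type nitrogen, which turns methyl into isobutyl.

Going by the values given here, the only measured step, a 1.5-fold higher number from compound 2 to compound 3 (0.17 log units; within the scatter), is a different change, hydrogen in place of fluoro on an aromatic carbon. Among the compounds with values here, it therefore gives only weak guidance, and no measured step covers this new change. In this assay, no shift beyond the scatter is expected, and the expected step is a 1.5-fold lower number from compound 3 to compound 4 (0.19 log units; within the scatter). For compound 4 the estimate is 130000 nM, with an expected range from 40000 nM to 300000 nM.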

Compound 4, half-maximal cytotoxic concentration: 102000 nM
Estimate against measurement, compound 4: 1.3-fold (0.11 log units) above; the measured number falls inside the stated range.
By their numbers in this assay, from the lowest: compounds 4, 2 and 3 (each within the scatter of the next).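

Until this point, the only change shown was a fluoro on an aromatic carbon; compound 4 opens a second place, the saturated chain carbon bound to an amide-type nitrogen, where methyl becomes isobutyl. In this assay, the step is a 2.0-fold lower number from compound 3 to compound 4 (0.29 log units; within the scatter), so this larger, branched chain can be carried at this place with no shift that stands out from repeated measurements. Nothing shown gives a reason for this step.

On these data alone, whether a longer chain, a ring, an amine or a carboxylic acid at the same place would also stay within the scatter remains open. So does whether isobutyl would read the same on the core of compound 2, which carries the extra fluoro.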